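This account rests on a few compounds, and the source may have more. Where it says the series, first, only, none or still open, it means among the compounds named here.

Compound 1 `O=C(Nc1ccccc1)c1c(NO)cc(-c2ccccc2)oc1=O` carries a phenyl on the amide-type nitrogen. In an ADME assay on Huh-7 cells (Homo sapiens) for cytotoxicity, read by a luciferase reporter and WST assay, with a stated time of 3 days (a higher number here means that more compound is tolerated, a lower number that less compound is tolerated), compound 1 gives 11600 nM. Compound 2 `O=C(Nc1ccc(F)cc1)c1c(NO)cc(-c2ccccc2)oc1=O` differs from it by one change: fluoro in place of hydrogen on an aromatic carbon. In this assay compound 2 reaches only a limit, > 20000 nM. That change made an at least 1.7-fold higher number from compound 1 to compound 2 (0.23 log units; that floor lies within the scatter). Compound 3 `O=C(NCCO)c1c(NO)cc(-c2ccccc2)oc1=O` has a different core, and the difference is 2-hydroxyethyl in place of phenyl on an amide-type nitrogen. In this assay compound 3 also stops at a limit, > 20000 nM. Compound 4 `O=C(NCCO)c1c(NO)cc(-c2ccc(F)cc2)oc1=O` has not yet been measured; it differs from compound 3 by fluoro in place of hydrogen on an aromatic carbon, the same change as from compound 1 to compound 2, at the same place. Because the limit of > 20000 nM in this assay, at which 2 of the 3 values shown sit, already holds compound 3, a step from compound 3 to compound 4 is expected to be a step that the limit leaves unreadable from compound 3 to compound 4, most likely again ending at that limit. Compound 4 is estimated at 25000 nM, between 12000 nM and 60000 nM.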

Compound 4, half-maximal cytotoxic concentration: > 20000 nM
Compound 4: no number, only a limit (the forecaster's own chance of this, stated with the estimate: 80%); the middle value does not contradict the limit.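

In this assay compound 3 and compound 4 both end at a limit, so the step between them cannot be read: the limit of > 20000 nM in this assay, at which 3 of the 4 values shown sit. The compounds shown leave open whether 4-fluorophenyl in place of phenyl changes how much compound is tolerated.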